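This account rests on a few compounds, and the source may have more. Where it says the series, first, only, none or still open, it means among the compounds named here.

The measured compounds:

Compound 1 `FC(F)(F)c1ccc(CN2CCN(Cc3cc(-c4ccc(OCc5ccccc5)cc4)on3)CC2)cc1` gives 2900 nM in a functional assay on MCF7 cells (Homo sapiens) for antiproliferative activity, read by sulforhodamine B assay, with a stated time of 72 h; a lower number here means a stronger inhibitor, a higher number a weaker inhibitor.
Compound 2 `Cc1cccc(COc2ccc(-c3cc(CN4CCN(Cc5ccc(C(F)(F)F)cc5)CC4)no3)cc2)c1` gives 4000 nM in this assay.
Compound 3 `N#Cc1ccc(COc2ccc(-c3cc(CN4CCN(Cc5ccc(C(F)(F)F)cc5)CC4)no3)cc2)cc1` gives 100 nM in this assay.

Among these three numbers compound 1 stands second highest. Its nearest neighbour is compound 2, with a 1.4-fold higher number from compound 1 to compound 2 (0.14 log units; within the scatter), a step within the scatter; its furthest is compound 3, with a 29-fold lower number from compound 1 to compound 3 (1.46 log units; beyond the scatter), a large step. The unmeasured compound 4 `COc1cccc(COc2ccc(-c3cc(CN4CCN(Cc5ccc(C(F)(F)F)cc5)CC4)no3)cc2)c1` differs from compound 1 by methoxy in place of hydrogen on an aromatic carbon.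

Among the compounds with values here, two measured steps bear on this change. The step of a 1.4-fold higher number from compound 1 to compound 2 (0.14 log units; within the scatter) places a methyl in place of hydrogen on an aromatic carbon and stays within the scatter. The step of a 29-fold lower number from compound 1 to compound 3 (1.46 log units; beyond the scatter) places a cyano in place of hydrogen on an aromatic carbon and is large, yet the step of a 40-fold lower number from compound 2 to compound 3 (1.60 log units; beyond the scatter) shows that 4-cyanophenyl and 3-methylphenyl sit far apart, so the small, within-scatter step to compound 2 is the closer guide. Compound 4 is therefore expected to show no step beyond the scatter, a 1.0-fold higher number from compound 1 to compound 4 (0.01 log units; within the scatter). The estimate for compound 4 is 3000 nM, within 1000 nM to 9000 nM.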

Compound 4, half-maximal inhibitory concentration: 2000 nM
Compound 4: the middle estimate sits 1.5-fold (0.18 log units) above what was measured, within the range that was stated.
By their numbers in this assay, from the lowest: compound 3; then compounds 4, 1 and 2 (each within the scatter of the next).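

Methoxy on this aromatic carbon, meta to a large group, leaves the number in this assay within the scatter of the compound without it (a 1.5-fold lower number from compound 1 to compound 4 (0.16 log units; within the scatter)), and exchanging methyl for methoxy at the same carbon also stays within the scatter (a 2.0-fold lower number from compound 2 to compound 4 (0.30 log units; within the scatter)). Compounds 1, 2 and 4 therefore form one group within the scatter, while compound 3 stands apart from the new compound by a large step (a 20-fold higher number from compound 3 to compound 4 (1.30 log units; beyond the scatter)), a step that changes both the substituent and where it sits on the ring. No measurement shown explains these numbers.

The compounds shown do not separate the nitrile itself from its place on the ring, since no nitrile sits where compound 4 carries its methoxy. They also leave open how a methoxy on the carbon bearing the nitrile in compound 3, or an amine or carboxylic acid on either carbon, would read.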